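A few compounds are considered here, and "the series" means these few. Any claim that something is new, unique, unknown or untested is made for them only; others in the source may bear on it.

Measured so far:
compound 1 `CS(=O)(=O)NC(=O)c1ccc(C2CC2c2ccc(OCc3c(-c4c(Cl)cccc4Cl)noc3C3CC3)cc2Cl)cc1` – in an assay on isolated protein for agonist activity at Bile acid receptor (Homo sapiens), read by FRET (a higher number here means that more compound is needed for the effect, a lower number that less compound is needed), compound 1 gives 90 nM
compound 2 `O=C(O)c1cncc(N2CC(O)(c3ccc(OCc4c(-c5c(Cl)cccc5Cl)noc4C4CC4)cc3Cl)C2)c1` – in this assay compound 2 gives 7 nM

Compound 2 has the lowest number of the two, and compound 1 sits well above it, a gap that is beyond the usual scatter. Compound 3 `O=C(O)c1cccc(N2CC(O)(c3ccc(OCc4c(-c5c(Cl)cccc5Cl)noc4C4CC4)cc3Cl)C2)c1` is not yet measured. It differs from compound 2 in one place: 3-carboxyphenyl in place of 5-carboxypyridin-3-yl on an amine nitrogen in a ring. Within the data shown here, no measured pair shows this kind of swap, so the expectation rests on compound 2 alone; a step of a 1.7-fold higher number from compound 2 to compound 3 (0.23 log units; within the scatter) in this assay is expected, at most modest. For compound 3 the estimate is 12 nM, with a likely range from 3 nM to 50 nM.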

Compound 3, half-maximal effective concentration: 54 nM
For compound 3 the middle estimate is 4.5-fold (0.65 log units) below the measured one, and the stated range ends below it.
By their numbers in this assay, from the lowest: compound 2; then compounds 3 and 1 (each within the scatter of the next).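

In this assay, putting 3-carboxyphenyl in place of 5-carboxypyridin-3-yl on the amine nitrogen of the four-membered ring gives a 7.7-fold higher number from compound 2 to compound 3 (0.89 log units; beyond the scatter) and so costs real potency. This position is therefore sensitive to a small edit: the two groups have the same number of heavy atoms and both carry a carboxylic acid, yet swapping one ring nitrogen for carbon means more compound is needed. Still open, from the compounds shown here alone, is whether an amide or a tetrazole in place of the carboxylic acid would keep the low number of compound 2. Nothing measured here gives a reason for the step.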